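Ring Contraction on the Fused Ether and Cell Tolerance

The source may report more compounds than this note shows. Statements on the series, on what has been measured and on what is new or still open speak of the compounds shown alone.

Three compounds share one core and differ only in the group on one aromatic carbon. Compound 1, `Cc1ccc(-c2c(C)c(-c3ccccc3)c(C(OC(C)(C)C)C(=O)O)c(C)c2NS(C)(=O)=O)cc1C`, carries a plain phenyl there. In an ADME assay on MT4 cells (Homo sapiens) for cytotoxicity, read by MTT assay, with a stated time of 4 days (a higher number here means that more compound is tolerated, a lower number that less compound is tolerated), compound 1 gives only a limit, > 50000 nM. Compound 2, `Cc1ccc(-c2c(C)c(-c3ccc(C)c(C)c3)c(C(OC(C)(C)C)C(=O)O)c(C)c2NS(C)(=O)=O)cc1C`, carries a 3,4-dimethylphenyl instead, and in this assay compound 2 gives 15000 nM; that change gave an at least 3.3-fold lower number from compound 1 to compound 2 (0.52 log units; beyond the scatter). Compound 3, `Cc1ccc(-c2c(C)c(-c3ccc4c(c3)CCCO4)c(C(OC(C)(C)C)C(=O)O)c(C)c2NS(C)(=O)=O)cc1C`, carries the fused ether group, and in this assay compound 3 gives 28000 nM, a number that sits within the scatter of the value of compound 2, so the two cannot be told apart. The steps leading to compound 3 were an at least 1.7-fold lower number from compound 1 to compound 3 (0.25 log units; that floor lies within the scatter) and a 1.9-fold higher number from compound 2 to compound 3 (0.27 log units; within the scatter).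

Compound 4, `Cc1ccc(-c2c(C)c(-c3ccc4c(c3)CCO4)c(C(OC(C)(C)C)C(=O)O)c(C)c2NS(C)(=O)=O)cc1C`, makes one further change: a group of 9 heavy atoms (8 carbon, 1 oxygen; one five-membered non-aromatic ring with 1 hetero atom, one six-membered aromatic ring of carbon only) in place of a group of 10 heavy atoms (9 carbon, 1 oxygen; one six-membered non-aromatic ring with 1 hetero atom, one six-membered aromatic ring of carbon only), on an aromatic carbon. Among the measured compounds shown here, no measured step alters the ring size of this fused group. For the measured compounds named here, the nearest comparison, a 1.9-fold higher number from compound 2 to compound 3 (0.27 log units; within the scatter), shows that replacing the whole group brought nothing beyond the scatter, and the only step beyond the scatter, an at least 3.3-fold lower number from compound 1 to compound 2 (0.52 log units; beyond the scatter), concerned 3,4-dimethylphenyl in place of phenyl. The expected step is therefore a 1.1-fold lower number from compound 3 to compound 4 (0.05 log units; within the scatter), within the scatter. Compound 4 is estimated at 25000 nM, with a range from 10000 nM to 60000 nM.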

Compound 4, half-maximal cytotoxic concentration: 38000 nM
Beside the measured number, compound 4's estimate is 1.5-fold (0.18 log units) below it, within the range that was stated.
By their numbers in this assay, from the lowest: compounds 2, 3 and 4 (each within the scatter of the next, the first and the last beyond it). At a limit, above all of these: compound 1.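

Changing the fused ether from a six-membered to a five-membered non-aromatic ring gives a 1.4-fold higher number from compound 3 to compound 4 (0.13 log units; within the scatter) in this assay, so this ring-size change at the aromatic carbon leaves no difference that can be told from the scatter. The comparison with the 3,4-dimethylphenyl group does separate, however: a 2.5-fold higher number from compound 2 to compound 4 (0.40 log units; beyond the scatter) lies beyond the scatter, whereas a 1.9-fold higher number from compound 2 to compound 3 (0.27 log units; within the scatter) does not, so among the groups shown only the five-membered fused ether is clearly apart from 3,4-dimethylphenyl. Compound 1 stands at a limit, so an at least 1.3-fold lower number from compound 1 to compound 4 (0.11 log units; that floor lies within the scatter) is only a floor, and whether plain phenyl truly differs from the five-membered fused ether cannot be read: the limit of > 50000 nM in this assay, at which 1 of the 4 values shown sits.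

The compounds shown leave open how the number responds at this position to a phenyl carrying an amine or a carboxylic acid, or to a methoxy group on an open phenyl in place of the closed ether ring. They also leave open whether the oxygen matters or the fused ring alone sets compound 4 apart from compound 2, a question that a matching fused ring of carbon only would address.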